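The compounds below may be only part of what the source reports. "The series", "measured", "known", "first", "only" and "open" are said of these compounds alone.

Measured compounds:
- Compound 1, `O=C1C=C(NCc2ccccc2)C(=O)c2c1nc1n2[C@H]2OC[C@@H](O)[C@H]2OC1`: in a functional assay on MCF7 cells (Homo sapiens) for inhibition, read by sulforhodamine B assay (a lower number here means a stronger inhibitor, a higher number a weaker inhibitor), compound 1 gives > 8000 nM, which is a limit of the assay rather than a number.
- Compound 2, `O=C1C=C(NC2CCCC2)C(=O)c2c1nc1n2[C@H]2OC[C@@H](O)[C@H]2OC1`: in this assay compound 2 gives > 16000 nM, again a limit and not a number.
- Compound 3, `Cc1ccc(NC2=CC(=O)c3nc4n(c3C2=O)[C@H]2OC[C@@H](O)[C@H]2OC4)cc1C`: in this assay compound 3 gives 2080 nM.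

For the measured compounds named here, compound 3 therefore holds the only real number among the three; the other two values are limits. Compound 4, `O=C1C=C(N2CCCC2)C(=O)c2c1nc1n2[C@H]2OC[C@@H](O)[C@H]2OC1`, is not yet measured. It differs from compound 3 in one place: pyrrolidin-1-yl in place of (3,4-dimethylphenyl)amino on a double-bonded ring carbon. Going by the values given here, two measured steps bear on this change, both ending at compound 3: an at least 3.8-fold lower number from compound 1 to compound 3 (0.58 log units; beyond the scatter) and an at least 7.6-fold lower number from compound 2 to compound 3 (0.88 log units; beyond the scatter). In both, a non-aromatic group on the amine nitrogen gave way to the 3,4-dimethylphenyl, and the number fell. Compound 4 reverses that direction, trading the 3,4-dimethylphenyl for a five-membered non-aromatic ring, so a step upward, toward weaker inhibition, is expected, likely large enough to reach a limit again. The expected step is a 9.6-fold higher number from compound 3 to compound 4 (0.98 log units; beyond the scatter). Compound 4 is estimated at 20000 nM, with a range from 5000 nM to 60000 nM.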

Compound 4, half-maximal inhibitory concentration: > 16000 nM
Compound 4: only a limit was reported (the forecaster's own chance of this, stated with the estimate: 60%); the middle value is on the limit's open side.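

In this assay, putting pyrrolidin-1-yl in place of (3,4-dimethylphenyl)amino on the double-bonded ring carbon gives an at least 7.6-fold higher number from compound 3 to compound 4 (0.88 log units; beyond the scatter). This is the first change shown that removes the amine hydrogen as well as the aromatic ring, yet compound 1 and compound 2 keep that hydrogen and also give no number, so losing it is not needed for this outcome. Compound 4 gives a limit of the assay, not a number, and it is the same limit as for compound 2: the limit of > 16000 nM in this assay, at which 2 of the 4 values shown sit.

The steps from compound 1 and from compound 2 to compound 4 join two limits and cannot be read, so the order among these three stays unknown. Also open, from the compounds shown here alone, is whether the aromatic ring alone or its two methyl groups matter in compound 3, which a plain phenylamino or a 4-chlorophenylamino group could separate.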